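Taking the chloro group off compound 2

The compounds below may be only part of what the source reports. "The series", "measured", "known", "first", "only" and "open" are said of these compounds alone.

In a functional assay on HCT-116 cells (Homo sapiens) for inhibition, read by colorimetric assay, with a stated time of 3 days (a higher number here means a weaker inhibitor, a lower number a stronger inhibitor), compound 1 (`CC(=O)c1ccc(NC(=O)CCCCCCNC(=O)C(O)(O)C(F)(F)F)cc1`) gives 12100 nM and compound 2 (`O=C(CCCCCCNC(=O)C(O)(O)C(F)(F)F)Nc1nc2ccc(Cl)cc2s1`) gives 11000 nM. These two numbers lie within the usual scatter of each other, so compound 2 cannot be separated from compound 1 on this read-out.

Compound 3 (`O=C(CCCCCCNC(=O)C(O)(O)C(F)(F)F)Nc1nc2ccccc2s1`) carries hydrogen in place of chloro on an aromatic carbon. Among the measured compounds shown here, no measured pair isolates this change, so the series offers no direct guide to its size. The structures of compound 1 and compound 2 differ by far more than this single atom, yet their values stay within the scatter. A step within the scatter is therefore expected in this assay, with a slight lean towards a higher number. The estimated step is a 1.2-fold higher number from compound 2 to compound 3 (0.07 log units; within the scatter). For compound 3 the expected value is 13000 nM, with an estimated range of 6000 nM to 30000 nM.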

Compound 3, half-maximal inhibitory concentration: 2370 nM
The estimate for compound 3 lay 5.5-fold (0.74 log units) above the measured number; the measured number lies below the stated range.
By their numbers in this assay, from the lowest: compound 3; then compounds 2 and 1 (each within the scatter of the next).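

In this assay, among the compounds shown here, the aromatic carbon that carries chloro in compound 2 proves sensitive to substitution: hydrogen in place of chloro gives a 4.6-fold lower number from compound 2 to compound 3 (0.67 log units; beyond the scatter) and moves the series beyond the scatter for the first time. The earlier pair gave no sign of this, since its two values could not be separated. With chloro gone, 1,3-benzothiazol-2-yl in place of 4-acetylphenyl on the amide-type nitrogen also gives a readable step, a 5.1-fold lower number from compound 1 to compound 3 (0.71 log units; beyond the scatter), so the tie between compound 1 and compound 2 holds only with chloro present.

As far as these compounds go, it remains open whether a fluorine atom or a methoxy group on this carbon would read like chloro or like hydrogen. From the compounds shown here alone, it is also open whether the chloro-to-hydrogen step persists with a shorter chain. Nothing available bears on the reason for this step.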